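Series notes: para substituent on the distal ring

The source may hold more compounds than are shown below. What is called first, only, known or untested is meant among the compounds shown, and "the series" means these compounds.

Measured so far:
compound 1 `COc1ccc(-c2ccc(COC3CN(C#N)C3)cc2)cc1` gives 0.94 nM in an assay on isolated protein for inhibition of N-acylethanolamine-hydrolyzing acid amidase (Homo sapiens), read by fluorescence, with a stated time of 90 min; on this read-out lower numbers stand for stronger inhibition and higher numbers for weaker inhibition
compound 2 `Cc1ccc(-c2ccc(COC3CN(C#N)C3)cc2)cc1` gives 0.46 nM in this assay

Compound 2 stands lowest of the two numbers; its nearest neighbour is compound 1, and the step of a 2.0-fold lower number from compound 1 to compound 2 (0.31 log units; beyond the scatter) lies beyond the scatter, though modest in size.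

Compound 3 `N#CN1CC(OCc2ccc(-c3ccc(F)cc3)cc2)C1` has not yet been measured. The change from compound 2 is fluoro in place of methyl on an aromatic carbon; cut one bond further out, it reads 4-methylphenyl to 4-fluorophenyl, with the new group sitting para to a large group.

Going by the values given here, only one measured step bears on this position, the exchange of methoxy for methyl from compound 1 to compound 2, and it was modest. A second swap of one small group for another at the same place is therefore expected to move this assay by a similarly small amount at most, if anything toward a slightly higher number. For compound 3 the estimate is 0.8 nM, with a range from 0.3 nM to 2.5 nM, which means an expected step of a 1.7-fold higher number from compound 2 to compound 3 (0.24 log units; within the scatter) that may well fall within the scatter.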

Compound 3, half-maximal inhibitory concentration: 0.68 nM
Compound 3: the middle estimate sits 1.2-fold (0.07 log units) above what was measured; the measured number falls inside the stated range.
By their numbers in this assay, from the lowest: compounds 2, 3 and 1 (each within the scatter of the next, the first and the last beyond it).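

Fluoro at this place gives a step within the scatter against both earlier groups in this assay: against methyl (a 1.5-fold higher number from compound 2 to compound 3 (0.17 log units; within the scatter)) and against methoxy (a 1.4-fold lower number from compound 1 to compound 3 (0.14 log units; within the scatter)). Compound 3 therefore cannot be ordered against either compound 1 or compound 2, and the step between those two remains the only one here beyond the scatter. The position, para to a large group on the distal ring, thus accepts a fluoro group in place of a carbon-based one without a step beyond the scatter, and no supporting data bear on why these three groups read so closely.

Still open, as far as these compounds go, is how far this tolerance extends at the same position, for example to an amine, a carboxylic acid or a longer chain such as n-butyl. The compounds shown also leave open whether the fluoro and methyl groups would read as closely on a different core.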